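A few compounds are considered here, and "the series" means these few. Any claim that something is new, unique, unknown or untested is made for them only; others in the source may bear on it.

- compound 1 `O=C1C(=Cc2ccc(Cl)cc2)C(=O)N(c2ccc(Cl)cc2)N1c1ccc(Cl)cc1` gives 28500 nM
- compound 2 `COc1ccc(C=C2C(=O)N(c3ccc(Cl)cc3)N(c3ccc(Cl)cc3)C2=O)cc1OC` gives > 128000 nM

In a functional assay on MCF7 cells (Homo sapiens) for cytotoxicity, read by MTT assay, with a stated time of 72 h (a higher number here means a weaker inhibitor, a lower number a stronger inhibitor), compound 2 has no exact number, only the limit > 128000 nM as its reading. Compound 3 `O=C1C(=Cc2ccccc2)C(=O)N(c2ccc(Cl)cc2)N1c1ccc(Cl)cc1` differs from it as follows: phenyl in place of 3,4-dimethoxyphenyl on a double-bonded chain carbon bound to a double-bonded ring carbon, with phenyl in place of 3,4-dimethoxyphenyl on a double-bonded chain carbon bound to a double-bonded ring carbon. For the measured compounds named here, one measured step bears on this change: an at least 4.4-fold higher number from compound 1 to compound 2 (0.65 log units; beyond the scatter), where 3,4-dimethoxyphenyl replaced 4-chlorophenyl at that same place. A step of similar size toward a lower number in this assay is therefore expected, estimated as an at least 2.8-fold lower number from compound 2 to compound 3 (0.45 log units; beyond the scatter) for this change. Compound 3 is expected at 45000 nM, within an estimated range from 18000 nM to 120000 nM in this assay's read-out.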

Compound 3, half-maximal inhibitory concentration: 20200 nM
Beside the measured number, compound 3's estimate is 2.2-fold (0.35 log units) above it, within the range that was stated.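

In this assay, phenyl at this place, on a double-bonded chain carbon bound to a double-bonded ring carbon, gives an at least 6.3-fold lower number from compound 2 to compound 3 (0.80 log units; beyond the scatter). Hydrogen in place of chloro on an aromatic carbon gives a 1.4-fold lower number from compound 1 to compound 3 (0.15 log units; within the scatter), so the drop in strength is tied to the 3,4-dimethoxyphenyl group and not to the loss of chloro. The reading of compound 2 is a limit, not a number, so the full size of that step stays open: the limit of > 128000 nM in this assay, at which 1 of the 3 values shown sits.

On these data alone, whether a single methoxy, a hydroxyl or an amine on this phenyl would keep the reading close to that of compound 3 remains open.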